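The source may hold more compounds than are shown below. What is called first, only, known or untested is meant among the compounds shown, and "the series" means these compounds.

Measured compounds in a functional assay on PC-3 cells (Homo sapiens) for antiproliferative activity, read by MTT assay, with a stated time of 72 h; on this read-out lower numbers stand for stronger inhibition and higher numbers for weaker inhibition:
compound 1, `COc1cc2ncnc(N3CCc4ccccc43)c2cc1NC(=O)/C=C/C(C)C`, gives 6530 nM
compound 2, `CCC/C=C/C(=O)Nc1cc2c(N3CCc4ccccc43)ncnc2cc1OC`, gives 4240 nM
compound 3, `CC(C)/C=C/C(=O)Nc1cc2c(N3CCCc4ccccc43)ncnc2cc1O[C@@H]1CCOC1`, gives 8510 nM

Compound 2 differs from compound 1 by propyl in place of isopropyl on a double-bonded chain carbon bound to a double-bonded chain carbon. That change gave a 1.5-fold lower number from compound 1 to compound 2 (0.19 log units; within the scatter). Compound 3 carries another core; the difference between the core of compound 3 and the core of compound 1 is not broken down here.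

Compound 4, `CCC/C=C/C(=O)Nc1cc2c(N3CCCc4ccccc43)ncnc2cc1O[C@@H]1CCOC1`, is still to be measured in this assay. It differs from compound 3 by propyl in place of isopropyl on a double-bonded chain carbon bound to a double-bonded chain carbon, the same change as that between compound 1 and compound 2. The change has been seen once, and that single step stayed within the scatter, so for compound 4 a step of about a 1.5-fold lower number from compound 3 to compound 4 (0.17 log units; within the scatter) is expected in this assay, resting on the earlier step of a 1.5-fold lower number from compound 1 to compound 2 (0.19 log units; within the scatter). Compound 4 is accordingly estimated at 5700 nM, with a range expected from 2800 nM to 11500 nM.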

Compound 4, half-maximal inhibitory concentration: 11800 nM
Compound 4: middle estimate off by 2.1-fold (0.32 log units), on the low side; measured number outside the range, above it.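

In this assay, propyl in place of isopropyl on a double-bonded chain carbon bound to a double-bonded chain carbon gave a 1.4-fold higher number from compound 3 to compound 4 (0.14 log units; within the scatter). Set beside the earlier step, the two readings on the two cores do not separate: the same change on two cores in this assay, a 1.5-fold lower number (0.19 log units; within the scatter) from compound 1 to compound 2 and a 1.4-fold higher number (0.14 log units; within the scatter) from compound 3 to compound 4, 2.1-fold (0.33 log units) apart, within the scatter of two such steps. This shows no core dependence of the change in this series, but it does not establish that the change carries over, since both steps lie within the scatter and two steps cannot distinguish a small effect from none.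

From the compounds shown here alone, whether a longer chain or an amine in place of propyl would give a step beyond the scatter on either core stays open.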